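The source may report more compounds than this note shows. Statements on the series, on what has been measured and on what is new or still open speak of the compounds shown alone.

Compound 3 `CCOC(=O)/C(=C\c1ccc(OC)c(O)c1)C(=O)c1cc(OC)c(OC)c(OC)c1` gives 870 nM in an ADME assay on K562 cells (Homo sapiens) for cytotoxicity, read by MTT assay, with a stated time of 5 days (on this read-out higher numbers stand for weaker inhibition and lower numbers for stronger inhibition), the lowest of the two numbers reported, with compound 1 `COc1ccc(/C=C(\C#N)C(=O)c2cc(OC)c(OC)c(OC)c2)cc1O` at 4200 nM. Compound 2 `COc1cc(C(=O)/C(C#N)=C/c2ccc(OC)c(OC)c2OC)cc(OC)c1OC` gives > 10000 nM, a limit of the assay rather than a number, (the limit of > 10000 nM in this assay, at which 1 of the 3 values shown sits). Going by the values given here, the one measured step, a 4.8-fold lower number from compound 1 to compound 3 (0.68 log units; beyond the scatter), concerns the group on the double-bonded chain carbon bound to a carbonyl carbon and a double-bonded chain carbon. Compound 4 `COc1ccc(/C=C(\F)C(=O)c2cc(OC)c(OC)c(OC)c2)cc1O` changes the same place: fluoro in place of ethoxycarbonyl on a double-bonded chain carbon bound to a carbonyl carbon and a double-bonded chain carbon. That step compares cyano with ethoxycarbonyl; fluoro is neither, and it bears on compound 4 only loosely. A modest rise rather than a further fall is expected. Compound 4 is estimated at 3000 nM in this assay, between 600 nM and 15000 nM, an expected 3.4-fold higher number from compound 3 to compound 4 (0.54 log units; beyond the scatter).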

Compound 4, half-maximal inhibitory concentration: 13.7 nM
Compound 4: the middle estimate sits 220-fold (2.34 log units) above what was measured, outside the stated range (below it).
By their numbers in this assay, from the lowest: compound 4; then compound 3; then compound 1. At a limit, above all of these: compound 2.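

In this assay, the group on this double-bonded chain carbon proves far more decisive than the earlier modest step suggested, with fluoro in place of ethoxycarbonyl giving a 64-fold lower number from compound 3 to compound 4 (1.80 log units; beyond the scatter). Fluoro in place of cyano gives a still wider step, a 310-fold lower number from compound 1 to compound 4 (2.49 log units; beyond the scatter), so this position can move the number by much more than the cyano and ethoxycarbonyl pair revealed. Nothing given here accounts for the size of these steps. The compounds shown leave open whether chloro, methyl or an amine on this carbon would match fluoro. They also leave open whether a bare hydrogen there would do the same.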